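The source may hold more compounds than are shown below. What is called first, only, known or untested is meant among the compounds shown, and "the series" means these compounds.

Compound 1 `Fc1ccc(NC(=S)Nc2cccc(C(F)(F)F)c2)cc1Cl` gives 20000 nM 
Compound 2 `Fc1ccc(NC(=S)Nc2cccc(C(F)(F)F)c2)cc1` gives 40000 nM 

In an ADME assay on Vero 76 cells (Chlorocebus sabaeus) for cytotoxicity, read by crystal violet staining, with a stated time of 96 h (on this read-out lower numbers stand for higher toxicity in this test and higher numbers for lower toxicity in this test), compound 2 reads 40000 nM and stands within the scatter of compound 1, so the two cannot be ranked. For the measured compounds named here, the only measured step (a 2.0-fold higher number from compound 1 to compound 2 (0.30 log units; within the scatter)) is hydrogen in place of chloro on an aromatic carbon.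

Compound 3 `Fc1cccc(NC(=S)Nc2cccc(C(F)(F)F)c2)c1` has not yet been measured. Its difference from compound 2 (3-fluorophenyl in place of 4-fluorophenyl on an amide-type nitrogen) is 3-fluorophenyl in place of 4-fluorophenyl on an amide-type nitrogen. The two have the same atoms, joined differently. Going by the values given here, no measured step makes this exchange, so the evidence is indirect: the one change seen, from compound 1 to compound 2 (a 2.0-fold higher number from compound 1 to compound 2 (0.30 log units; within the scatter)), did not leave the scatter. In this assay no step beyond the scatter is therefore expected, in either direction, and the estimate implies only a small expected shift (a 1.3-fold lower number from compound 2 to compound 3 (0.12 log units; within the scatter)). For compound 3 the estimated half-maximal cytotoxic concentration is 30000 nM and four of five measurements are expected to fall between 12000 nM and 80000 nM on this estimate.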

Compound 3, half-maximal cytotoxic concentration: 20000 nM
Compound 3: the middle estimate sits 1.5-fold (0.18 log units) above what was measured, within the range that was stated.
By their numbers in this assay, from the lowest: compounds 1, 3 and 2 (each within the scatter of the next).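

In this assay, exchanging 4-fluorophenyl for 3-fluorophenyl on the amide-type nitrogen gives a 2.0-fold lower number from compound 2 to compound 3 (0.30 log units; within the scatter) and so yields no ranking of compound 2 and compound 3. The earlier step concerned only the loss of a chloro group from an aromatic carbon, whereas this one keeps the same atoms and changes only how they are joined, and this isomeric exchange also stays inside the scatter, so the read-out does not separate these two fluorophenyl groups on this nitrogen. No measurement shown here offers an explanation for this result, and nothing beyond the cytotoxicity numbers themselves bears on it.

The compounds shown leave open whether the read-out stays this flat when the fluorine on this ring gives way to a group of another kind, such as an amine, a carboxylic acid or a longer alkyl chain. They also leave open what would follow if the thiocarbonyl were replaced by a carbonyl or if the trifluoromethyl group, common to all three compounds, were exchanged for a nitrile.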